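The source may hold more compounds than are shown below. What is called first, only, known or untested is meant among the compounds shown, and "the series" means these compounds.

Within the data shown here, compound 1 `CC(C)(C)OC(=O)NCC1CCCN(C(=O)CN2CN(c3ccccc3)C3(CCN(C(=O)c4ccc(C5CCCCC5)cc4)CC3)C2=O)C1` is one of only two compounds measured in an assay on HEK293 cells for displacement of a labelled ligand from NPC1-like intracellular cholesterol transporter 1 (Homo sapiens); a higher number here means a weaker inhibitor, a lower number a stronger inhibitor; there compound 1 gives 3800 nM, the lower of the two numbers. Compound 2 `CC(C)(C)c1ccc(C(=O)N2CCC3(CC2)C(=O)N(CC(=O)N2CCCCC2CCO)CN3c2ccccc2)cc1` gives 6100 nM in this assay, and the two values lie within the scatter of each other, so nothing on these numbers separates compound 1 from compound 2. Compound 3 `CC1CCCN(C(=O)CN2CN(c3ccccc3)C3(CCN(C(=O)c4ccc(C5CCCCC5)cc4)CC3)C2=O)C1` has not yet been measured. It differs from compound 1 in one place: hydrogen in place of (tert-butoxycarbonyl)amino on a saturated chain carbon bound to a saturated ring carbon. Among the measured compounds shown here, no measured pair shows this change, so its effect in this assay cannot be read from the data at hand. Compound 3, with hydrogen in place of (tert-butoxycarbonyl)amino on a saturated chain carbon bound to a saturated ring carbon, is expected to stay close in value, the expected step of a 1.2-fold higher number from compound 1 to compound 3 (0.07 log units; within the scatter) being no larger than the scatter in either direction. Compound 3 is therefore estimated at 4500 nM, with a range from 1200 nM to 17000 nM.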

Compound 3, half-maximal inhibitory concentration: 3600 nM
Estimate against measurement, compound 3: 1.3-fold (0.10 log units) above, within the range that was stated.
By their numbers in this assay, from the lowest: compounds 3, 1 and 2 (each within the scatter of the next).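

Putting hydrogen in place of (tert-butoxycarbonyl)amino on a saturated chain carbon bound to a saturated ring carbon gives a 1.1-fold lower number from compound 1 to compound 3 (0.02 log units; within the scatter) in this assay. Among these compounds, this pair is the first direct reading of the change, and it shows that the whole group of 8 heavy atoms, with its hydrogen-bond donor and acceptors, can go from this position while the number stays within the scatter. No other information on these compounds bears on this result.

The compounds shown leave open whether a free amine or a carboxylic acid at this position, or a longer chain ending in either, would also stay within the scatter. With only the ((tert-butoxycarbonyl)amino)methyl and methyl compounds compared here, an intermediate group such as an acetamide cannot be read from them.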